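The source may hold more compounds than are shown below. What is called first, only, known or untested is meant among the compounds shown, and "the series" means these compounds.

Measured compounds:
compound 1 `Nc1ncnc2c1c(-c1cc(C3CC3)on1)nn2C1CCOCC1`, 1930 nM
compound 2 `CC(C)n1nc(-c2cc(-c3ccc(F)cc3)on2)c2c(N)ncnc21`, > 10000 nM
compound 3 `CC(C)c1cc(-c2nn(C(C)C)c3ncnc(N)c23)no1`, 5900 nM

In an assay on BaF3 cells for inhibition of proto-oncogene tyrosine-protein kinase receptor Ret variant V804M (Homo sapiens), read by MTT assay, with a stated time of 48 h (on this read-out higher numbers stand for weaker inhibition of growth and lower numbers for stronger inhibition of growth), compound 1 gives 1930 nM, the lowest of the two numbers shown; compound 3 gives 5900 nM. The value of compound 2 is a limit of the assay, > 10000 nM (the limit of > 10000 nM in this assay, at which 1 of the 3 values shown sits). Going by the values given here, the only measured step, an at least 1.6-fold lower number from compound 2 to compound 3 (0.22 log units; that floor lies within the scatter), changes the group on the oxazole and not the group on the aromatic nitrogen, so it does not bear on the step to compound 4 `Cn1nc(-c2cc(C3CC3)on2)c2c(N)ncnc21`. That step is methyl in place of oxan-4-yl on an aromatic nitrogen. Among the compounds with values here, with no measured step at this position, only a modest move is expected, and toward a higher number, since compound 3 with a small alkyl on that nitrogen gives 5900 nM. Compound 4 is estimated at 4000 nM, range 1500 nM to 12000 nM, a step of a 2.1-fold higher number from compound 1 to compound 4 (0.32 log units; beyond the scatter).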

Compound 4, concentration for 50% growth inhibition: 5560 nM
Estimate against measurement, compound 4: 1.4-fold (0.14 log units) below; measured number inside the range.
By their numbers in this assay, from the lowest: compound 1; then compounds 4 and 3 (each within the scatter of the next). At a limit, above all of these: compound 2.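

Methyl in place of oxan-4-yl on the aromatic nitrogen gives a 2.9-fold higher number from compound 1 to compound 4 (0.46 log units; beyond the scatter) in this assay, the first step read at this position with the 5-cyclopropyl-1,2-oxazol-3-yl group held fixed. The number at this position therefore moves with the group on that nitrogen, and oxan-4-yl stands on the lower side of the pair. Nothing measured in the series accounts for this step.

Open, on these data alone, is whether the lower number follows the six-membered ring or its oxygen, a question that cyclohexyl or a piperidine ring on the same nitrogen would address. As far as these compounds go, how a longer chain there would read also stays open.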